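This account rests on a few compounds, and the source may have more. Where it says the series, first, only, none or still open, it means among the compounds named here.

Compound 1 `Cc1ccc(C(O)c2cn(C[C@H]3COC(C)(C)O3)nn2)cc1` was tested in a functional assay on B16 cells (Mus musculus) for cytotoxicity, read by MTT assay, with a stated time of 48 h; a lower number here means a stronger inhibitor, a higher number a weaker inhibitor. In this assay compound 1 returns only a limit, > 100000 nM, rather than a measured number. Two companion compounds stand in the same place. Compound 2 `COc1cccc(Cn2cc(-c3ccc(OC)c(OC)c3OC)nn2)c1` likewise gives a limit in this assay, > 100000 nM. Compound 3 `COc1ccc(-c2cn(CCCO)nn2)cc1` also gives a limit, > 100000 nM. Among the measured compounds shown here, every value so far therefore sits at the limit of > 100000 nM in this assay, at which 3 of the 3 values shown sit, and no real number exists yet to compare against.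

Compound 4 `Cc1ccc(C(O)c2cn(CC3COC(C)(C)O3)nn2)cc1` is next to be measured. Its difference from compound 1 is the two compounds have the same atoms and bonds; at least one stereo element is drawn with a configuration in one of them and without one in the other: 1 of 2 stereo elements differ; a stereocentre at a saturated ring carbon is drawn S in compound 1 and without a configuration in compound 4; the atoms and bonds are identical, and only the drawn configuration at one saturated ring carbon is left open in compound 4. For the measured compounds named here, no step between measured compounds is available here, so there is nothing to calibrate a change against. Compound 1 gives a limit, > 100000 nM. The step expected from compound 1 to compound 4, a step that the limit leaves unreadable from compound 1 to compound 4, is none beyond the scatter. Compound 4 is therefore expected to give around 150000 nM, with a range from 50000 nM to 500000 nM, and most probably once more only a limit.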

Compound 4, half-maximal inhibitory concentration: > 100000 nM
Compound 4: only a limit was reported (the forecaster's own chance of this, stated with the estimate: 90%); the middle value lies beyond the limit too.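

In this assay compound 4 and compound 1 both give only a limit, so no step can be read between them: the limit of > 100000 nM in this assay, at which 4 of the 4 values shown sit.

The compounds shown leave open whether the drawn configuration at the saturated ring carbon changes activity, and which structure would give a measurable value in this assay at all.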